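The compounds below may be only part of what the source reports. "The series", "measured", "known", "first", "only" and "open" are said of these compounds alone.

Measured so far in a functional assay on NCI-H2122 cells (Homo sapiens) for inhibition, read by microscopy, with a stated time of 10 days; on this read-out higher numbers stand for weaker inhibition and lower numbers for stronger inhibition:
compound 1 `Cn1nc(-c2ccccc2)c2c1OC(N)=C(C#N)C2c1ccc(F)cc1` gives > 10000 nM, a limit of the assay.
compound 2 `N#CC1=C(N)Oc2c(c(-c3ccccc3)nn2-c2ccccc2)C1c1ccc(F)cc1` gives 4100 nM.
compound 3 `COc1ccc(-c2nn(C)c3c2C(c2ccc(F)cc2)C(C#N)=C(N)O3)cc1OC` gives > 10000 nM, also a limit.

Compound 1 therefore stands only at the limit of > 10000 nM in this assay, at which 2 of the 3 values shown sit, with no resolved number. Compound 4 `COc1ccc(C2C(C#N)=C(N)Oc3c2c(-c2ccccc2)nn3C)cc1` differs from it by methoxy in place of fluoro on an aromatic carbon. The measured steps touch other positions: replacing methyl with phenyl on the aromatic nitrogen gave an at least 2.4-fold lower number from compound 1 to compound 2 (0.38 log units; beyond the scatter), while the 3,4-dimethoxyphenyl for phenyl change gave a step that the two limits leave unreadable from compound 1 to compound 3. Neither bears on the 4-fluorophenyl group, so nothing measured predicts this step. Compound 4 is expected to remain near the limit, at an estimated 12000 nM with a range of 4000 nM to 40000 nM. The step that the limit leaves unreadable from compound 1 to compound 4 is expected to lie within scatter.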

Compound 4, half-maximal inhibitory concentration: > 10000 nM
Compound 4: a limit, no number; the forecaster's own chance of this, stated with the estimate: 70%; the middle value lies beyond the limit too.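

No step can be read between compound 1 and compound 4, as both sit at a limit of the assay: the limit of > 10000 nM in this assay, at which 3 of the 4 values shown sit.
The compounds shown leave open whether 4-methoxyphenyl in place of 4-fluorophenyl changes inhibition at all.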